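Silyl ether size at the primary oxygen: compound 4

The source may report more compounds than this note shows. Statements on the series, on what has been measured and on what is new or still open speak of the compounds shown alone.

For the measured compounds named here, compound 3 `C=C1CC[C@@H]2[C@](C)(CO[Si](C(C)C)(C(C)C)C(C)C)[C@H](OC(C)=O)CC[C@@]2(C)[C@@H]1C/C=C1/C(=O)OC[C@H]1OC(C)=O` stands second highest of the three numbers so far in a functional assay on Col2 cells (Homo sapiens) for cytotoxicity, read by sulforhodamine B assay; on this read-out higher numbers stand for an effect only at larger amounts of compound and lower numbers for an effect already at smaller amounts. Compound 3 gives 13.6 uM. Its nearest neighbour is compound 2 `C=C1CC[C@@H]2[C@](C)(COC(C)=O)[C@H](O)CC[C@@]2(C)[C@@H]1C/C=C1/C(=O)OC[C@H]1OC(C)=O`, which gives 15.2 uM; the furthest is compound 1 `C=C1CC[C@@H]2[C@](C)(CO[Si](C)(C)C(C)(C)C)[C@H](O)CC[C@@]2(C)[C@@H]1C/C=C1/C(=O)OC[C@H]1OC(C)=O`, which gives 8.94 uM. All three numbers sit within the scatter of one another, so no ordering among them is claimed.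

Compound 4 `C=C1CC[C@@H]2[C@](C)(CO[Si](C)(C)C(C)(C)C)[C@H](OC(C)=O)CC[C@@]2(C)[C@@H]1C/C=C1/C(=O)OC[C@H]1OC(C)=O` differs from compound 3 at the oxygen on the saturated carbon: a group of 7 heavy atoms (6 carbon, 1 silicon; no ring) in place of a group of 10 heavy atoms (9 carbon, 1 silicon; no ring), on an oxygen on a saturated carbon. Going by the values given here, the only measured step that bears on this oxygen is a 1.7-fold higher number from compound 1 to compound 2 (0.23 log units; within the scatter), where a group of 3 heavy atoms replaced a group of 7 heavy atoms at the same place. Among the compounds with values here, that exchange, larger in kind than the one from compound 3 to compound 4, moved the number by an amount within the scatter. The change here, a group of 7 heavy atoms in place of a group of 10 heavy atoms, both silicon-bearing, is expected to do no more; no step beyond the scatter is expected in this assay, in either direction, and the step of a 1.1-fold lower number from compound 3 to compound 4 (0.05 log units; within the scatter) is the estimate.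

Compound 4 is therefore expected to give 12 uM in this assay, estimated within 6 uM to 24 uM.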

Compound 4, concentration for half-maximal effect: 2.23 uM
Estimate against measurement, compound 4: 5.4-fold (0.73 log units) above; the measured number lies below the stated range.
By their numbers in this assay, from the lowest: compound 4; then compounds 1, 3 and 2 (each within the scatter of the next).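

Working notes on the oxygen on a saturated carbon: in this assay, the group of 7 heavy atoms in place of the group of 10 heavy atoms gives a step beyond the scatter (a 6.1-fold lower number from compound 3 to compound 4 (0.79 log units; beyond the scatter)), so the number responds to a change between two silicon-bearing groups at this oxygen. The earlier step at the same oxygen, an exchange of a group of 7 heavy atoms for a group of 3 heavy atoms, stayed within the scatter (a 1.7-fold higher number from compound 1 to compound 2 (0.23 log units; within the scatter)), so the size of a step here does not follow the size of the exchange in these compounds, and the response depends on which groups are exchanged. With the group of 7 heavy atoms held in place, acetyl in place of hydrogen on an oxygen on a saturated carbon also gives a step beyond the scatter (a 4.0-fold lower number from compound 1 to compound 4 (0.60 log units; beyond the scatter)), and no supporting measurement accompanies either step to account for them.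

Still open, on these data alone, is how a methyl ether, a benzyl ether or a free hydroxyl on the first oxygen would read with the acetyl kept in place. Also open, as far as these compounds go, is whether a propionyl or a longer acyl chain in place of that acetyl would move the number further in this assay.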